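Bromo Core with a Methylphenyl Urea: Expected Potency

The source may hold more compounds than are shown below. What is called first, only, known or untested is meant among the compounds shown, and "the series" means these compounds.

Compound 1, `Cc1ccc(NC(=O)Nc2nc(-c3cc4ccccc4o3)cs2)cc1`, gives 500 nM in a physicochemical assay, with a stated time of 6 min; on this read-out higher numbers stand for weaker inhibition and lower numbers for stronger inhibition.
Compound 2, `O=C(Nc1ccc(F)cc1)Nc1nc(-c2cc3cc(Br)ccc3o2)cs1`, reaches only a limit of the assay, > 200000 nM.
Compound 3, `COc1cccc(NC(=O)Nc2nc(-c3cc4cc(Br)ccc4o3)cs2)c1`, likewise reaches only a limit, > 200000 nM.

Compound 3 thus stands at the top of the range, where the assay reports no number. The step that the two limits leave unreadable from compound 2 to compound 3 cannot be read, because both values sit at the limit of > 200000 nM in this assay, at which 2 of the 3 values shown sit. Compound 4, `Cc1ccc(NC(=O)Nc2nc(-c3cc4cc(Br)ccc4o3)cs2)cc1`, differs from compound 3 as follows: 4-methylphenyl in place of 3-methoxyphenyl on an amide-type nitrogen. Within the data shown here, no measured step reads on this change, so the expectation rests on compound 3 alone. Compound 4 is expected to stay near the limit, with an at least 1.6-fold lower number from compound 3 to compound 4 (0.22 log units; that floor lies within the scatter) in this assay. The estimate for compound 4 is 120000 nM, within 20000 nM to 300000 nM.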

Compound 4, half-maximal inhibitory concentration: > 200000 nM
Compound 4: only a limit was reported; the forecaster's own chance of this, stated with the estimate: 60%; middle value at least 1.6-fold (0.22 log units) away from the limit.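

In this assay, among these compounds, bromo in place of hydrogen on an aromatic carbon gives an at least 400-fold higher number from compound 1 to compound 4 (2.60 log units; beyond the scatter), the first readable step for this change. With 4-methylphenyl on the amide-type nitrogen, compound 4 still gives only a limit, > 200000 nM. The steps among compound 2, compound 3 and compound 4 cannot be read, because their values all sit at one bound: the limit of > 200000 nM in this assay, at which 3 of the 4 values shown sit.

Going by these compounds, it remains open whether chloro at that aromatic carbon would give a readable number. On these data alone, it also remains open whether an amine on the phenyl ring would bring a bromo compound off the limit.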